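The compounds below may be only part of what the source reports. "The series", "measured", "known", "first", "only" and "open" are said of these compounds alone.

In a functional assay on NCI-H460 cells (Homo sapiens) for antiproliferative activity, read by CCK-8 assay, with a stated time of 72 h, tested at 8 uM (a higher number here means a stronger effect of the compound at the concentration tested, a lower number a weaker effect), three compounds built on the shared core have been measured. Compound 2 `Cc1ccc(Nc2nc(Cl)nc3c2ncn3Cc2ccc(C(=O)Nc3ccccc3N)cc2)cc1` gives 82.5%, the highest of the three numbers. Compound 1 `CCC(C)n1cnc2c(NCc3ccc(C(=O)Nc4ccccc4N)cc3)nc(Cl)nc21` gives 67.7%, a number lower than that of compound 2 by more than the usual scatter of this measurement. Compound 3 `Nc1ccccc1NC(=O)/C=C/c1ccc(Cn2cnc3c(Nc4cccc(Cl)c4)nc(Cl)nc32)cc1` gives 29.4%, the lowest of the set and far below compound 2. Compound 2 thus stands as the strongest of the three measured, and it is the point from which the next compound departs.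

Compound 4 `Nc1ccccc1NC(=O)c1ccc(Cn2cnc3c(Nc4ccc(-c5ccccn5)cc4)nc(Cl)nc32)cc1` has not yet been measured in this assay. It differs from compound 2 in one place: pyridin-2-yl in place of methyl on an aromatic carbon. Among the compounds with values here, no pair of measured compounds differs in only this way, and no step between measured compounds is available for comparison, so nothing measured here shows what such a change does on this core. The expectation therefore rests on the change alone and on the level of compound 2. The expected step is a number 10.5 percentage points lower from compound 2 to compound 4 (beyond the scatter), a modest loss that may or may not exceed the scatter. Compound 4 is expected to give about 72% in this assay, with the estimate ranging from 48% to 90%.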

Compound 4, a percentage reported as inhibition, at one concentration (the size of the read-out at that concentration, not a potency): 30.8%
Beside the measured number, compound 4's estimate is 41.2 percentage points above it, and the stated range ends above it.
By their numbers in this assay, from the lowest: compounds 3 and 4 (each within the scatter of the next); then compound 1; then compound 2.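

Within the data shown here, replacing methyl with pyridin-2-yl gives a number 51.7 percentage points lower from compound 2 to compound 4 (beyond the scatter) in this assay and is the first step on the shared core that can be read from one change alone. It shows that the place on the aromatic ring para to a large group is not indifferent to what it carries: the level of compound 2 does not hold when 4-methylphenyl becomes 4-(pyridin-2-yl)phenyl, a change that adds a six-membered aromatic ring with one nitrogen. Nothing at hand explains why the read-out falls with this change.

With only methyl and pyridin-2-yl to compare at this place, the compounds shown leave open whether the loss goes with the added ring itself or with its nitrogen, which a plain phenyl group at the same place would help to separate. They also leave open whether a small group other than methyl, such as a chlorine atom or a methoxy group, would stay near the level of compound 2 or fall toward that of compound 4.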